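Fluorine on the anilide ring of a thiosemicarbazone cytotoxin

A few compounds are considered here, and "the series" means these few. Any claim that something is new, unique, unknown or untested is made for them only; others in the source may bear on it.

Compound 2 `CC(=NNC(=S)Nc1ccccc1)c1ccccn1` and compound 3 `C/C(=N\NC(=S)Nc1ccccc1)c1ccccn1` share a core that differs only as the two compounds have the same atoms and bonds; at least one stereo element is drawn with a configuration in one of them and without one in the other: 1 of 1 stereo elements differ; a double bond is drawn without a configuration in compound 2 and E in compound 3; in a functional assay on U-87MG ATCC cells (Homo sapiens) for cytotoxicity, read by MTT assay, with a stated time of 48 h (a higher number here means a weaker inhibitor, a lower number a stronger inhibitor), compound 2 gives 1.4 nM and compound 3 gives 1.4 nM, so no change at the digits printed from compound 2 to compound 3 (within the scatter), consistent with the fact that one of compounds 2 and 3 is drawn with a defined configuration and the other without, at the place where they differ. Compound 1 `CC(=NNC(=S)Nc1cccc(F)c1)c1ccccn1` carries fluoro in place of hydrogen on an aromatic carbon and in this assay compound 1 gives 18 nM, a step of a 13-fold higher number from compound 2 to compound 1 (1.11 log units; beyond the scatter). Compound 4 `C/C(=N\NC(=S)Nc1ccc(F)cc1)c1ccccn1` carries the same kind of change, (fluoro in place of hydrogen on an aromatic carbon), though the place is para to a large group rather than meta to a large group. Because the same kind of change gave a 13-fold higher number from compound 2 to compound 1 (1.11 log units; beyond the scatter), compound 4 is expected to lie at 6 nM, between 1.5 nM and 30 nM, an estimated step of a 4.3-fold higher number from compound 3 to compound 4 (0.63 log units; beyond the scatter).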

Compound 4, half-maximal inhibitory concentration: 10 nM
Beside the measured number, compound 4's estimate is 1.7-fold (0.22 log units) below it; the measured number falls inside the stated range.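

In this assay, fluoro in place of hydrogen on an aromatic carbon gives a 7.1-fold higher number from compound 3 to compound 4 (0.85 log units; beyond the scatter), and this step does not differ from the earlier one: the same change on two cores in this assay, a 13-fold higher number (1.11 log units; beyond the scatter) from compound 2 to compound 1 and a 7.1-fold higher number (0.85 log units; beyond the scatter) from compound 3 to compound 4, 1.8-fold (0.26 log units) apart, within the scatter of two such steps Across these two cases the change therefore carries over in direction and, within the scatter, in size, even though the fluoro of compound 4 sits para to a large group and that of compound 1 sits elsewhere on the ring. It does not show transfer to a truly different core, since the two starting compounds have the same atoms and bonds: the fact that one of compounds 2 and 3 is drawn with a defined configuration and the other without, at the place where they differ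

The compounds shown leave open whether chloro, methoxy or an amine at the same place would move the number as fluoro does. They also leave open whether the fluoro step would hold on a core of different atoms.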